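Ester in place of acid on the phenyl arm

The source may hold more compounds than are shown below. What is called first, only, known or untested is meant among the compounds shown, and "the series" means these compounds.

Compound 3 `CC#CCn1c(N2CCC[C@@H](N)C2)nc2c1c(=O)n(Cc1c(Cl)cccc1C(=O)O)c(=O)n2C` carries a 2-carboxy-6-chlorophenyl group on a saturated chain carbon bound to an aromatic nitrogen. In an ADME assay on isolated protein for inhibition of Dipeptidyl peptidase 9 (Homo sapiens), with stated times of 15 min, 60 s and 20 min (a higher number here means a weaker inhibitor, a lower number a stronger inhibitor), compound 3 gives > 100000 nM, which is a limit of the assay and not a number. Compound 1 `CC#CCn1c(N2CCC[C@@H](N)C2)nc2c1c(=O)n(Cc1ccccc1C(=O)OC)c(=O)n2C` gives > 100000 nM in this assay, again a limit rather than a number. Compound 2 `CC#CCn1c(N2CCC[C@@H](N)C2)nc2c1c(=O)n(Cc1cc(Br)ccc1C(=O)O)c(=O)n2C` gives > 100000 nM, likewise a limit. Every value shown thus sits at the limit of > 100000 nM in this assay, at which 3 of the 3 values shown sit, so the steps a step that the two limits leave unreadable from compound 1 to compound 3, a step that the two limits leave unreadable from compound 2 to compound 3 and a step that the two limits leave unreadable from compound 1 to compound 2 cannot be read in size or direction.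

Compound 4 `CC#CCn1c(N2CCC[C@@H](N)C2)nc2c1c(=O)n(Cc1cc(Cl)ccc1C(=O)OC)c(=O)n2C` differs from compound 3 in one place: 5-chloro-2-(methoxycarbonyl)phenyl in place of 2-carboxy-6-chlorophenyl on a saturated chain carbon bound to an aromatic nitrogen. The change from compound 1 to compound 3, which exchanges a methoxycarbonyl for a carboxy group, is the measured step closest to this one, and the change from compound 2 to compound 3 touches the halogen, but neither can be sized. Compound 1 already holds the methoxycarbonyl group and still sits at the limit, so no readable movement in this assay is expected from compound 3 to compound 4, and the step that the limit leaves unreadable from compound 3 to compound 4 is estimated as essentially none. Compound 4 is therefore expected to give about 200000 nM in this assay, within 50000 nM to 1000000 nM, most probably again as a limit.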

Compound 4, half-maximal inhibitory concentration: > 100000 nM
Compound 4: only a limit was reported (the forecaster's own chance of this, stated with the estimate: 85%); the middle value lies beyond the limit too.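

No new step can be read from compound 4 to compound 1, compound 2 or compound 3 in this assay, since each result is a limit of the assay and not a number: the limit of > 100000 nM in this assay, at which 4 of the 4 values shown sit.

The compounds shown leave open how far apart these four lie in this assay, and whether exchanging ester, acid or halogen changes anything there.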